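The source may hold more compounds than are shown below. What is called first, only, known or untested is meant among the compounds shown, and "the series" means these compounds.

Two measured compounds share a core that carries a ketone-linked chain bearing a thioether and two carboxylic acids; compound 1 is `Cc1ccc(C(=O)CC(SCC(=O)O)C(=O)O)c(C)c1` and compound 2 is `Cc1ccc(C(=O)CC(SCC(=O)O)C(=O)O)cc1`. In a functional assay on HeLa cells (Homo sapiens) (on this read-out lower numbers stand for stronger inhibition and higher numbers for weaker inhibition), compound 1 gives 3830 nM, and in this assay compound 2 gives 17300 nM. Among the measured compounds shown here, compound 2 therefore stands as the higher of the two numbers, and its only neighbour is compound 1, reached by the single step of a 4.5-fold higher number from compound 1 to compound 2 (0.65 log units; beyond the scatter). The next compound to consider, compound 3, is `Cc1ccc(C(=O)CC(SCC(=O)O)C(=O)O)c(Cl)c1`. Compared with compound 2 it carries chloro in place of hydrogen on an aromatic carbon. For the measured compounds named here, the only measured step that bears on this change is the one from compound 1 to compound 2, in which removing a methyl group from an aromatic carbon gave a modest rise in the number; placing a chloro on an aromatic carbon of compound 2 is a change of the same kind in the opposite sense, so a modest fall in this assay is expected, meaning a 3.8-fold lower number from compound 2 to compound 3 (0.58 log units; beyond the scatter). For compound 3 the estimate in this assay is 4500 nM, with a likely range from 1500 nM to 14000 nM.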

Compound 3, half-maximal inhibitory concentration: 4730 nM
Estimate against measurement, compound 3: 1.1-fold (0.02 log units) below, and the stated range covers the measured number.
By their numbers in this assay, from the lowest: compounds 1 and 3 (each within the scatter of the next); then compound 2.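

This result shows that the gain seen with methyl at this aromatic carbon, ortho to a large group and meta to a methyl group, is not unique to methyl: in this assay, placing a chloro group there in compound 2 gives a 3.7-fold lower number from compound 2 to compound 3 (0.56 log units; beyond the scatter) as a modest but real shift beyond the usual scatter. Exchanging the methyl group of compound 1 for chloro gives a 1.2-fold higher number from compound 1 to compound 3 (0.09 log units; within the scatter) and stays within the scatter, so in this assay the two groups cannot be told apart, and both compound 1 and compound 3 differ clearly from compound 2, which has hydrogen at this carbon. Nothing available here accounts for this match between methyl and chloro, so the result records what happens at this position without explaining it.

Going by these compounds, it remains open whether other groups on this carbon, such as fluoro, methoxy, trifluoromethyl or an amine, would follow methyl and chloro or would instead stay with hydrogen. On these data alone, it is also open whether a chloro group on a different carbon of the same ring would produce a comparable shift.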